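A few compounds are considered here, and "the series" means these few. Any claim that something is new, unique, unknown or untested is made for them only; others in the source may bear on it.

Compound 1 `CC(=O)Nc1ccc2[nH]c(C)nc2c1`: 1260000 nM
Compound 2 `Cc1ccc2[nH]c(C)nc2c1`: 479000 nM

For the measured compounds named here, in an ADME assay on microsomes from liver for inhibition of cytochrome P450 2B1 (Rattus norvegicus) (a higher number here means a weaker inhibitor, a lower number a stronger inhibitor), compound 2 stands lowest of the two numbers; the only measured step, a 2.6-fold lower number from compound 1 to compound 2 (0.42 log units; beyond the scatter), is a modest one. Compound 3 `CCOc1ccc2[nH]c(C)nc2c1` differs from compound 2 by ethoxy in place of methyl on an aromatic carbon. That one step, from compound 1 to compound 2, concerns the same aromatic carbon but exchanges acetamido for methyl, so nothing measured bears directly on an ethoxy group entering here. The step expected in this assay is therefore a 1.0-fold higher number from compound 2 to compound 3 (0.02 log units; within the scatter), none beyond the scatter. Compound 3 is estimated at 500000 nM, with a range from 200000 nM to 1300000 nM.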

Compound 3, half-maximal inhibitory concentration: 56200 nM
Beside the measured number, compound 3's estimate is 8.9-fold (0.95 log units) above it, outside the stated range (below it).
By their numbers in this assay, from the lowest: compound 3; then compound 2; then compound 1.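

In this assay, ethoxy in place of methyl on this aromatic carbon gives an 8.5-fold lower number from compound 2 to compound 3 (0.93 log units; beyond the scatter), and ethoxy in place of acetamido gives a 22-fold lower number from compound 1 to compound 3 (1.35 log units; beyond the scatter). The position therefore spans a wider range than the first pair showed, with compound 3 the strongest inhibitor of the three. Nothing available explains why ethoxy stands apart here. As far as these compounds go, whether methoxy or a longer chain such as propoxy would lower the number further remains open, as does how a free amine or a carboxylic acid at this carbon would compare.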